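Pyrazole series at the EP1 receptor: reversed amide with oxane

The source may hold more compounds than are shown below. What is called first, only, known or untested is meant among the compounds shown, and "the series" means these compounds.

Three compounds of the series have numbers in an assay on CHO-K1 cells for displacement of a labelled ligand from prostaglandin E2 receptor EP1 subtype (Homo sapiens); on this read-out higher numbers stand for weaker inhibition and lower numbers for stronger inhibition. Compound 1 `Cc1cc(C(=O)O)nn1Cc1cc(Br)ccc1OCc1ccccc1`, which carries the free carboxylic acid, gives 6.31 nM. Compound 3 `Cc1cc(C(N)=O)nn1Cc1cc(Cl)ccc1OCC(C)C` gives 126 nM. Compound 2 `Cc1cc(C(=O)Nc2ccc(F)cc2)nn1Cc1cc(Cl)ccc1OCc1ccccc1` gives 79.4 nM.

On these three numbers compound 2 stands second highest. Its nearest neighbour is compound 3, whose number lies within the usual scatter of that of compound 2, so the two cannot be told apart. Among the measured compounds shown here, the furthest is compound 1, whose number is lower by a margin beyond the scatter; among the three, the free acid is the only compound with a clearly stronger number.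

Compound 4 `Cc1cc(NC(=O)C2CCOCC2)nn1Cc1cc(Cl)ccc1OCc1ccccc1` is not yet measured. It differs from compound 2 in one place: ((oxan-4-yl)carbonyl)amino in place of (4-fluorophenyl)carbamoyl on an aromatic carbon. The (4-fluorophenyl)carbamoyl group leaves, and a ((oxan-4-yl)carbonyl)amino group enters on the same aromatic carbon, so the amide is turned round and the aromatic ring is exchanged for a six-membered non-aromatic ring with one hetero atom.

For the measured compounds named here, no measured pair shows this change, so the expectation rests on the three numbers alone. The step of a 3.1-fold higher number from compound 2 to compound 4 (0.50 log units; beyond the scatter) is expected to be a modest rise toward a weaker number, possibly within the scatter. Compound 4 is estimated at 250 nM, with a range from 60 nM to 1000 nM.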

Compound 4, half-maximal inhibitory concentration: 63.1 nM
Compound 4: middle estimate off by 4.0-fold (0.60 log units), on the high side; the measured number falls inside the stated range.
By their numbers in this assay, from the lowest: compound 1; then compounds 4, 2 and 3 (each within the scatter of the next).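

In this assay the exchange gives a 1.3-fold lower number from compound 2 to compound 4 (0.10 log units; within the scatter), so compounds 2 and 4 cannot be told apart. Among the compounds shown here, this is the first reading at this aromatic carbon of a pair that differs in one place, and it shows that the (4-fluorophenyl)carbamoyl group can give way to ((oxan-4-yl)carbonyl)amino with no change beyond the scatter. At this position, then, neither the aromatic ring of that group nor the original direction of the amide is required to keep the number of compound 2 in this assay, at least when the two changes are made together.

Because both changes sit in one step, the pair cannot show what either does alone, and they may act independently or offset each other; a reversed amide still carrying the 4-fluorophenyl group, or a cyclohexane ring in place of the oxane ring, would separate the amide direction from the ring and the ring oxygen. No measurement at hand gives a reason for this result.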